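From Compound 2 to Compound 3 on the Aromatic Nitrogen

This account rests on a few compounds, and the source may have more. Where it says the series, first, only, none or still open, it means among the compounds named here.

Compound 1, `CN1CCC(n2cc(S(=O)(=O)c3ccccc3Cl)c3cccnc32)C1`, in a functional assay on HeLa cells for antagonist activity at 5-hydroxytryptamine receptor 6 (Homo sapiens), read by cAMP accumulation and immunoassay; a lower number here means a stronger inhibitor, a higher number a weaker inhibitor: 91 nM
Compound 2, `CN1CCC(n2cc(S(=O)(=O)c3ccc(Cl)cc3)c3cccnc32)C1`, in this assay: 95 nM

Among the measured compounds shown here, compound 2 carries the higher of the two numbers measured so far, but its nearest neighbour is compound 1, and the step of a 1.0-fold higher number from compound 1 to compound 2 (0.02 log units; within the scatter) lies within the scatter, so the two cannot be told apart on these data. That step concerns only the chlorophenyl on the sulfonyl sulfur.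

The unmeasured compound 3, `O=S(=O)(c1ccc(Cl)cc1)c1cn(C2CCCNC2)c2ncccc12`, differs from compound 2 in another place: piperidin-3-yl in place of 1-methylpyrrolidin-3-yl on an aromatic nitrogen. For the measured compounds named here, no measured step touches the group on the aromatic nitrogen; the single step in hand, a 1.0-fold higher number from compound 1 to compound 2 (0.02 log units; within the scatter), sits at the other end of the molecule and shows only that moving the chlorine on the phenyl leaves this assay unchanged within the scatter. The expectation for compound 3 must therefore rest on compound 2 alone, with a wide range in both directions. Compound 3 is expected to give 80 nM in this assay, within 20 nM to 320 nM. That estimate means a step of a 1.2-fold lower number from compound 2 to compound 3 (0.07 log units; within the scatter), expected to stay within the scatter.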

Compound 3, half-maximal inhibitory concentration: 682 nM
The estimate for compound 3 lay 8.5-fold (0.93 log units) below the measured number; measured number above the stated range.
By their numbers in this assay, from the lowest: compounds 1 and 2 (each within the scatter of the next); then compound 3.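

Among the compounds shown here, the group on the aromatic nitrogen does register in this assay: the change to piperidin-3-yl gives a 7.2-fold higher number from compound 2 to compound 3 (0.86 log units; beyond the scatter) and so lies beyond the scatter, whereas the only earlier step, a 1.0-fold higher number from compound 1 to compound 2 (0.02 log units; within the scatter) on the sulfonyl side, did not. The two groups have the same heavy-atom count and the same carbon and nitrogen content, so this step arises with no change in composition, only in how the atoms are joined: a five-membered ring becomes a six-membered one, and 0 hydrogen-bond donors become 1 hydrogen-bond donor. Nothing available accounts for the higher number.

Because ring size and donor count change together, the data cannot say which of them goes with the step, and a 1-methylpiperidin-3-yl or a pyrrolidin-3-yl group on the same aromatic nitrogen would pull the two apart. As far as these compounds go, it also remains open whether the piperidin-3-yl group would give a similar step with the 2-chlorophenyl on the sulfonyl sulfur, as in compound 1.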